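Three Aminopyrazine Amides and a Fourth Not Yet Measured

The compounds below may be only part of what the source reports. "The series", "measured", "known", "first", "only" and "open" are said of these compounds alone.

Compound 1 `Cc1noc(C)c1-c1cnc(N)c(Oc2ccc(C(=O)Nc3cc(Cl)ccn3)cc2)n1`, compound 2 `Cc1noc(C)c1-c1cnc(N)c(Oc2ccc(C(=O)Nc3ncccc3Cl)cc2)n1` and compound 3 `Cn1cc(-c2cnc(N)c(Oc3ccc(C(=O)Nc4cc(Cl)ccn4)cc3)n2)cn1` were tested in a functional assay on U-87MG ATCC cells for inhibition, with U-87 MG (Homo sapiens) as the target, read by MTT assay, with a stated time of 72 h; on this read-out higher numbers stand for weaker inhibition and lower numbers for stronger inhibition. In this assay compound 1 gives 70800 nM, compound 2 gives 45600 nM and compound 3 gives 47900 nM. The change from compound 1 to compound 2 is 3-chloropyridin-2-yl in place of 4-chloropyridin-2-yl on an amide-type nitrogen, and it made a step of a 1.6-fold lower number from compound 1 to compound 2 (0.19 log units; within the scatter). The change from compound 1 to compound 3 is 1-methyl-1H-pyrazol-4-yl in place of 3,5-dimethyl-1,2-oxazol-4-yl on an aromatic carbon, with a step of a 1.5-fold lower number from compound 1 to compound 3 (0.17 log units; within the scatter). Compound 2 and compound 3 are not separated by a measured step; their two values lie close to each other.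

Compound 4 `Cn1cc(-c2cnc(N)c(Oc3ccc(C(=O)Nc4ncccc4Cl)cc3)n2)cn1` has not yet been measured in this assay. It differs from compound 3 by 3-chloropyridin-2-yl in place of 4-chloropyridin-2-yl on an amide-type nitrogen. This is the same change as that from compound 1 to compound 2, now made on the core of compound 3; the two cores differ by 1-methyl-1H-pyrazol-4-yl in place of 3,5-dimethyl-1,2-oxazol-4-yl on an aromatic carbon. The place where the change occurs is described in the same words for both pairs, so the change is regarded as the same one.

An expectation for compound 4 rests on the earlier step: because a 1.6-fold lower number from compound 1 to compound 2 (0.19 log units; within the scatter) was small, compound 4 is expected to move from compound 3 by about a 1.5-fold lower number from compound 3 to compound 4 (0.19 log units; within the scatter). Compound 4 is therefore estimated at 31000 nM in this assay, with a range expected from 15000 nM to 65000 nM.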

Compound 4, half-maximal inhibitory concentration: 37600 nM
Estimate against measurement, compound 4: 1.2-fold (0.08 log units) below; the range from low to high includes it.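

In this assay, 3-chloropyridin-2-yl in place of 4-chloropyridin-2-yl on the amide-type nitrogen gave a 1.3-fold lower number from compound 3 to compound 4 (0.11 log units; within the scatter) on the core carrying 1-methyl-1H-pyrazol-4-yl, and this step stands alongside the earlier one on the core carrying 3,5-dimethyl-1,2-oxazol-4-yl: the same change on two cores in this assay, a 1.6-fold lower number (0.19 log units; within the scatter) from compound 1 to compound 2 and a 1.3-fold lower number (0.11 log units; within the scatter) from compound 3 to compound 4, 1.2-fold (0.09 log units) apart, within the scatter of two such steps. The second change, 1-methyl-1H-pyrazol-4-yl in place of 3,5-dimethyl-1,2-oxazol-4-yl on an aromatic carbon, gave a 1.2-fold lower number from compound 2 to compound 4 (0.08 log units; within the scatter) and also matched its earlier counterpart: the same change on two cores in this assay, a 1.5-fold lower number (0.17 log units; within the scatter) from compound 1 to compound 3 and a 1.2-fold lower number (0.08 log units; within the scatter) from compound 2 to compound 4, 1.2-fold (0.09 log units) apart, within the scatter of two such steps. Across these four compounds, then, neither change reads differently on one core than on the other, but every step lies within the scatter, so this agreement is only between steps too small to tell apart from repeat variation, and it shows neither that either change has a real effect nor that a larger step would carry over in the same way.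

The compounds shown leave open whether a nitrile or a methoxy group in place of the chlorine on the pyridine would move the number beyond the scatter. On these data alone, it is also open how an amine or a carboxylic acid in place of the 1-methyl-1H-pyrazol-4-yl group would read, and whether the two changes would still carry over on such a core.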